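From dimethylamino to amino on the shared core

The compounds below may be only part of what the source reports. "The series", "measured", "known", "first", "only" and "open" are said of these compounds alone.

In a functional assay on SW480 cells (Homo sapiens) for antiproliferative activity, read by MTT assay, with a stated time of 48 h (a lower number here means a stronger inhibitor, a higher number a weaker inhibitor), compound 1 (`CCCCCCC(CCO)n1cnc2c(N)ncnc21`) gives > 50000 nM as a limit of the assay and not a number. In this assay, within the data shown here, compound 2 (`CCCCCCCCCCC(CCO)n1cnc2c(N(C)C)ncnc21`) stands at 3320 nM as the only actual number so far. Compound 3 (`CCCCCCCCCCC(CCO)n1cnc2c(N)ncnc21`) is still unmeasured and, relative to compound 2, carries amino in place of dimethylamino on an aromatic carbon. Among the measured compounds shown here, no measured step bears on this change, so a modest weakening in this assay is expected, only slightly beyond the usual scatter. An estimated 1.8-fold higher number from compound 2 to compound 3 (0.26 log units; within the scatter) is what this amounts to. Compound 3 is expected near 6000 nM with an estimated 1500 nM to 25000 nM as its range.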

Compound 3, half-maximal inhibitory concentration: 1200 nM
The estimate for compound 3 lay 5.0-fold (0.70 log units) above the measured number; measured number outside the range, below it.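

In this assay, among these compounds, amino in place of dimethylamino on an aromatic carbon gives a 2.8-fold lower number from compound 2 to compound 3 (0.44 log units; beyond the scatter), the first measured step at this position, and it runs toward the stronger number. Butyl in place of hydrogen on a saturated chain carbon gives an at least 41-fold lower number from compound 1 to compound 3 (1.61 log units; beyond the scatter), so chain length counts for far more here than this change at the aromatic carbon. That second step rests on compound 1, whose value is a limit of the assay: the limit of > 50000 nM in this assay, at which 1 of the 3 values shown sits.

As far as these compounds go, whether methylamino at the same aromatic carbon would fall between these two groups stays open. So does whether a longer chain would lower the number further.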